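From 3-(trifluoromethyl)phenyl to pyridin-4-yl on a shared core

A few compounds are considered here, and "the series" means these few. Any claim that something is new, unique, unknown or untested is made for them only; others in the source may bear on it.

Compound 1 `CC(C)=CCC/C(C)=C/CC/C(C)=C/CC[C@@H]1[C@@]2(C)CC/C(=N\OCc3cn(-c4ccc(F)cc4)nn3)C(C)(C)[C@@H]2CC[C@@]1(C)O` gives 21600 nM
Compound 2 `CC(C)=CCC/C(C)=C/CC/C(C)=C/CC[C@@H]1[C@@]2(C)CC/C(=N\OCc3cn(-c4ccccc4C#N)nn3)C(C)(C)[C@@H]2CC[C@@]1(C)O` gives 25100 nM
Compound 3 `CC(C)=CCC/C(C)=C/CC/C(C)=C/CC[C@@H]1[C@@]2(C)CC/C(=N\OCc3cn(-c4cccc(C(F)(F)F)c4)nn3)C(C)(C)[C@@H]2CC[C@@]1(C)O` gives 11800 nM

These numbers come from a functional assay on DU-145 cells (Homo sapiens) for cytotoxicity, read by MTT assay, with a stated time of 48 h (a lower number here means a stronger inhibitor, a higher number a weaker inhibitor), and the three compounds differ only in the group on an aromatic nitrogen of a five-membered aromatic ring with 3 nitrogen. Compound 3 shares the low end of the three numbers with compound 1, the two lying within the scatter of each other. The gap on the other side is a 2.1-fold lower number from compound 2 to compound 3 (0.33 log units; beyond the scatter) and counts as modest.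

Compound 4 `CC(C)=CCC/C(C)=C/CC/C(C)=C/CC[C@@H]1[C@@]2(C)CC/C(=N\OCc3cn(-c4ccncc4)nn3)C(C)(C)[C@@H]2CC[C@@]1(C)O` carries pyridin-4-yl in place of 3-(trifluoromethyl)phenyl at that same place, a change counted as pyridin-4-yl in place of 3-(trifluoromethyl)phenyl on an aromatic nitrogen in full. Among the compounds with values here, the steps that bear on it are the other swaps there: a 1.2-fold higher number from compound 1 to compound 2 (0.07 log units; within the scatter) and a 1.8-fold lower number from compound 1 to compound 3 (0.26 log units; within the scatter) together with the gap above. Within the data shown here, all of them are small, yet none brings in a ring with a hetero atom, so the data hold no direct precedent. With compound 3 at 11800 nM at the low end, a modest rise is the likelier outcome. In this assay the step expected is a 1.9-fold higher number from compound 3 to compound 4 (0.29 log units; within the scatter) and so about as large as the largest seen so far. Compound 4 is expected at 23000 nM with an estimated range of 10000 nM to 50000 nM overall.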

Compound 4, half-maximal inhibitory concentration: 17400 nM
Beside the measured number, compound 4's estimate is 1.3-fold (0.12 log units) above it; low and high end bracket the measured number.
By their numbers in this assay, from the lowest: compounds 3, 4, 1 and 2 (each within the scatter of the next, the first and the last beyond it).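

In this assay, within the data shown here, pyridin-4-yl is the first group at this position whose ring holds a hetero atom, and it leaves the number within the scatter of all three carbon-only rings, with a 1.5-fold higher number from compound 3 to compound 4 (0.17 log units; within the scatter) and a 1.4-fold lower number from compound 2 to compound 4 (0.16 log units; within the scatter) and a 1.2-fold lower number from compound 1 to compound 4 (0.09 log units; within the scatter) as the steps. The change removes the trifluoromethyl group, gives a smaller group and adds a hydrogen-bond acceptor, yet none of this produces a step that can be told from the scatter, so a ring nitrogen here is compatible with cytotoxicity in the same range as the carbon-only rings. No measurement is available that would explain why the change has so little effect on the number.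

The compounds shown leave open whether the place of the ring nitrogen matters, as a pyridin-2-yl or pyridin-3-yl group would show. They also leave open whether anything other than a directly attached aromatic ring can move the number further, for example a benzyl group, a plain hexyl chain, or a phenyl ring bearing an amine or a carboxylic acid.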